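Changing the benzyl group: from compound 2 to compound 3

The source may hold more compounds than are shown below. What is called first, only, known or untested is meant among the compounds shown, and "the series" means these compounds.

Measured so far in a functional assay on HepG2 cells (Homo sapiens) for inhibition, read by MTT assay, with a stated time of 72 h; on this read-out lower numbers stand for stronger inhibition and higher numbers for weaker inhibition:
- compound 1 `O=C1/C(=C\c2ccccc2)c2c(ncn2COCc2ccccc2)CCN1Cc1ccc(Cl)cc1`: 47900 nM
- compound 2 `CC(C)(C)c1ccc(CN2CCc3ncn(COCc4ccccc4)c3/C(=C/c3ccccc3)C2=O)cc1`: 18000 nM

Compound 2 holds the lower of the two numbers, at 18000 nM. Among the measured compounds shown here, the only measured step is a 2.7-fold lower number from compound 1 to compound 2 (0.43 log units; beyond the scatter), modest in size, with tert-butyl in place of chloro on an aromatic carbon.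

Compound 3 `O=C1/C(=C\c2ccccc2)c2c(ncn2COCc2ccccc2)CCN1Cc1ccc2ccccc2c1` is the next to be read in this assay. It differs from compound 2 in one place: naphthalen-2-yl in place of 4-(tert-butyl)phenyl on a saturated chain carbon bound to an amide-type nitrogen in a ring.

For the measured compounds named here, that measured step also falls within the group on this saturated chain carbon, but no measured compound carries naphthalen-2-yl. Going by the values given here, with a 2.7-fold lower number from compound 1 to compound 2 (0.43 log units; beyond the scatter) as the only guide, a modest step at most is expected, leaning towards a higher number. The expected step is a 1.4-fold higher number from compound 2 to compound 3 (0.14 log units; within the scatter). The estimate for compound 3 is 25000 nM, with an expected range of 9000 nM to 60000 nM.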

Compound 3, half-maximal inhibitory concentration: 23700 nM
Compound 3: middle estimate off by 1.1-fold (0.02 log units), on the high side; the measured number falls inside the stated range.
By their numbers in this assay, from the lowest: compounds 2 and 3 (each within the scatter of the next); then compound 1.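

In this assay, naphthalen-2-yl in place of 4-(tert-butyl)phenyl gives a 1.3-fold higher number from compound 2 to compound 3 (0.12 log units; within the scatter): at the same heavy-atom count, a second six-membered aromatic ring of carbon leaves the read-out indistinguishable from that of the tert-butyl compound. Naphthalen-2-yl in place of 4-chlorophenyl gives a 2.0-fold lower number from compound 1 to compound 3 (0.31 log units; beyond the scatter), so two different groups on this saturated chain carbon now read lower than the 4-chlorophenyl group of compound 1, though both steps from it remain modest. Nothing available explains this level reading or the gap to compound 1.

Open, going by these compounds, is whether an amine or a carboxylic acid on the aromatic ring of this benzyl group would shift the number in either direction. Also open, on these data alone, is what a longer chain in place of the single saturated carbon would do to the read-out.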